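Piperidine Variation on the Shared Core of Compound 3

The compounds below may be only part of what the source reports. "The series", "measured", "known", "first", "only" and "open" are said of these compounds alone.

Of the compounds shown here, three on the shared core have been measured in a functional assay on CHO-K1 cells for antagonist activity at transient receptor potential cation channel subfamily V member 1 (Homo sapiens), read by FLIPR; on this read-out lower numbers stand for stronger inhibition and higher numbers for weaker inhibition. Compound 1 `CC1CCC(Nc2nc(C(F)(F)F)ccc2CNC(=O)C(C)c2ccc(NS(C)(=O)=O)c(F)c2)CC1` gives 27.2 nM. Compound 2 `CC(C(=O)NCc1ccc(C(F)(F)F)nc1NCc1cccnc1)c1ccc(NS(C)(=O)=O)c(F)c1` is reported as "not active" (no number reported). Compound 3 `CC(C(=O)NCc1ccc(C(F)(F)F)nc1N1CCCCC1C)c1ccc(NS(C)(=O)=O)c(F)c1` gives 2.9 nM. Within the data shown here, the only single-site step among them runs a 9.4-fold lower number from compound 1 to compound 3 (0.97 log units; beyond the scatter), with 2-methylpiperidin-1-yl in place of (4-methylcyclohexyl)amino on an aromatic carbon. Compound 3 therefore holds the lowest of the two numbers, and compound 1 is its nearest neighbour with a higher number beyond the scatter.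

Compound 4 `CC(C)OC1CCN(c2nc(C(F)(F)F)ccc2CNC(=O)C(C)c2ccc(NS(C)(=O)=O)c(F)c2)CC1` continues at the same position. The change is 4-isopropoxypiperidin-1-yl in place of 2-methylpiperidin-1-yl on an aromatic carbon. Among the measured compounds shown here, no measured step bears directly on this exchange, since both measured changes at this position concern other groups. The step from compound 1 to compound 3 does show that the group on this aromatic carbon can shift the number substantially, so a noticeable change for compound 4 is plausible in either direction; the pair keeps the same six-membered non-aromatic ring with 1 hetero atom, which argues against a very large step. For compound 4 the estimated value is 8 nM, with a range from 2 nM to 40 nM. The expected step is a 2.8-fold higher number from compound 3 to compound 4 (0.44 log units; beyond the scatter).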

Compound 4, inhibition constant: 3 nM
Beside the measured number, compound 4's estimate is 2.7-fold (0.43 log units) above it; the range from low to high includes it.
By their numbers in this assay, from the lowest: compounds 3 and 4 (each within the scatter of the next); then compound 1.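

In this assay, 4-isopropoxypiperidin-1-yl in place of 2-methylpiperidin-1-yl gives a 1.0-fold higher number from compound 3 to compound 4 (0.01 log units; within the scatter), so this aromatic carbon next to the ring nitrogen accepts two differently substituted piperidines with no difference beyond the scatter, even though the entering group has 10 heavy atoms against 7 and includes an oxygen. The (4-methylcyclohexyl)amino group of compound 1 now stands apart from a second piperidine as well, with a 9.1-fold lower number from compound 1 to compound 4 (0.96 log units; beyond the scatter), so the earlier step to compound 3 is no longer the only one of its kind at this position. The data offer no measured reason why the two piperidines read alike in this assay.

The two piperidines differ both in the substituent and in where it sits, so the compounds shown cannot separate these two changes, and 4-methylpiperidin-1-yl or unsubstituted piperidin-1-yl would be needed to do so. As far as these compounds go, it also remains open whether the tolerance seen here extends to a piperidine carrying an amine or a carboxylic acid, or to morpholin-4-yl, at this aromatic carbon.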